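The source may hold more compounds than are shown below. What is called first, only, known or untested is meant among the compounds shown, and "the series" means these compounds.

Working notes on the series. The shared core carries a short ether chain ending in an amine, and the amine is the variable end. Going by the values given here, compound 1 `CC(CN1CCCC1)Oc1cccc2ccc(N)nc12` is the reference point: in an assay on cells with melanin-concentrating hormone receptor 1 (Homo sapiens) as the target, read by radioligand binding (a lower number here means a stronger inhibitor, a higher number a weaker inhibitor), compound 1 gives 70 nM, the lowest of the two numbers so far. Among the compounds with values here, compound 2 `CC(CNc1ccc2[nH]ncc2c1)Oc1cccc2ccc(N)nc12` is the only other measured member; in this assay compound 2 gives 530 nM, which stands well beyond the scatter above compound 1, so the one change made so far at this end of the chain has cost potency.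

Compound 3 `CC(CNCc1ccsc1)Oc1cccc2ccc(N)nc12` is the next member to go into this assay. Against compound 1 the change is ((thiophen-3-yl)methyl)amino in place of pyrrolidin-1-yl on a saturated chain carbon, two bonds along the chain from an oxygen on an aromatic ring. Within the data shown here, no measured step of this exact kind exists in the set, so the expectation rests on what compound 1 and compound 2 show: the pyrrolidinyl end of compound 1 is so far the only one that gives a low number, and the one departure from it, compound 2 at 530 nM, went upward. For compound 3 a step upward of modest size, a 2.1-fold higher number from compound 1 to compound 3 (0.33 log units; beyond the scatter), is therefore expected, though it could fall within the scatter. Compound 3 is estimated at 150 nM, with a range from 40 nM to 600 nM.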

Compound 3, half-maximal inhibitory concentration: 10 nM
Compound 3: middle estimate off by 15-fold (1.18 log units), on the high side; measured number below the stated range.
By their numbers in this assay, from the lowest: compound 3; then compound 1; then compound 2.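

In this assay, the change to ((thiophen-3-yl)methyl)amino on the saturated chain carbon gives a 7.0-fold lower number from compound 1 to compound 3 (0.85 log units; beyond the scatter), so pyrrolidin-1-yl no longer marks the low end of the series and leaving it does not by itself cost potency. The amine end can therefore move the number in either direction: compound 2 reads 530 nM and compound 3 reads 10 nM, so two ends that both replace the pyrrolidine ring with an aromatic group on an amino nitrogen fall on opposite sides of compound 1. Nothing at hand accounts for the gain seen with compound 3.

The compounds shown leave open whether the gain belongs to the thiophene ring itself, since a benzylamino, a ((furan-3-yl)methyl)amino or a ((thiophen-2-yl)methyl)amino end would be needed to separate the ring and its point of attachment from the rest of the group. They also leave open how much depends on the single methylene link and on the hydrogen on the amine nitrogen, which a (2-(thiophen-3-yl)ethyl)amino end or an N-methyl tertiary amine would test.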